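The source may hold more compounds than are shown below. What is called first, only, known or untested is meant among the compounds shown, and "the series" means these compounds.

In a functional assay on ASPC1 cells (Homo sapiens) for cytotoxicity (on this read-out higher numbers stand for weaker inhibition and lower numbers for stronger inhibition), three compounds sharing one core have been measured. Going by the values given here, compound 1 `COc1ccc2nc(NC(=O)CCCCC(=O)NO)sc2c1` gives 23.9 ug/mL, the only exact number so far. Compound 2 `CS(=O)(=O)c1ccc2nc(NC(=O)CCCCC(=O)NO)sc2c1` gives > 30 ug/mL, which is a limit of the assay and not a number. From the compounds shown here alone, compound 3 `O=C(CCCCC(=O)Nc1nc2ccc([N+](=O)[O-])cc2s1)NO` gives > 30 ug/mL, which is also a limit, so its exact place on the scale is unknown.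

Compound 4 `CCOc1ccc2nc(NC(=O)CCCCC(=O)NO)sc2c1` differs from compound 3 by one change: ethoxy in place of nitro on an aromatic carbon. In words, this is ethoxy in place of nitro on an aromatic carbon. The most useful measured comparison is the swap of methoxy for nitro, an at least 1.2-fold higher number from compound 1 to compound 3 (0.09 log units; that floor lies within the scatter). The swap of methoxy for methylsulfonyl, an at least 1.2-fold higher number from compound 1 to compound 2 (0.09 log units; that floor lies within the scatter), gives a similar reading. Among the compounds with values here, neither comparison shows a firm gap, but compound 1 at 23.9 ug/mL is the only measured compound with an alkoxy-type ether group in that place, so it serves as the anchor. A modest move towards a lower number, meaning stronger inhibition, is expected here: an at least 1.3-fold lower number from compound 3 to compound 4 (0.13 log units; that floor lies within the scatter). For compound 4 the expected value is 22 ug/mL, with an estimated range from 13 ug/mL to 30 ug/mL.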

Compound 4, half-maximal inhibitory concentration: 16.7 ug/mL
Beside the measured number, compound 4's estimate is 1.3-fold (0.12 log units) above it, and the stated range covers the measured number.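

Compound 4 gives this position a second exact number, and the two ethers cannot be told apart: a methyl in place of hydrogen on the ether chain gives a 1.4-fold lower number from compound 1 to compound 4 (0.16 log units; within the scatter). Ethoxy in place of nitro gives an at least 1.7-fold lower number from compound 3 to compound 4 (0.25 log units; that floor lies within the scatter), and ethoxy in place of methylsulfonyl gives an at least 1.7-fold lower number from compound 2 to compound 4 (0.25 log units; that floor lies within the scatter), so the ethers may differ from these two groups, but no firm gap is shown. Those two steps are only floors because each starts from a limit and not from a number: the limit of > 30 ug/mL in this assay, at which 2 of the 4 values shown sit.

From the compounds shown here alone, how far nitro and methylsulfonyl truly lie from the ethers remains unknown, as their exact values are hidden behind the limit. Going by these compounds, it also remains open whether a longer ether chain such as butoxy, or an amine or a hydroxyl on this aromatic carbon, would move the number beyond the scatter.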